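The source may hold more compounds than are shown below. What is called first, only, known or untested is meant among the compounds shown, and "the series" means these compounds.

Measured in a functional assay on K562 cells (Homo sapiens), read by MTT assay, with a stated time of 72 h; on this read-out higher numbers stand for weaker inhibition and lower numbers for stronger inhibition:
- compound 1 `COc1ncnc2c1c(-c1cc3ccccc3o1)cn2[C@@H]1O[C@H](CO)[C@@H](O)[C@H]1O`: 20900 nM
- compound 2 `C#Cc1cn([C@@H]2O[C@H](CO)[C@@H](O)[C@H]2O)c2ncnc(OC)c12`: 300 nM
- compound 3 `CSc1ncnc2c1c(-c1ccccc1)cn2[C@@H]1O[C@H](CO)[C@@H](O)[C@H]1O`: > 20000 nM (a limit, not a number)

Of the two true numbers, compound 1 has the higher at 20900 nM, while compound 2 reads 300 nM. Compound 3 gives > 20000 nM, which is a limit of the assay. Among the compounds with values here, compound 3 also differs from compound 1 in more than one place, so it offers no clean step.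

The next compound, compound 4 `CNc1ncnc2c1c(-c1cc3ccccc3o1)cn2[C@@H]1O[C@H](CO)[C@@H](O)[C@H]1O`, keeps the 1-benzofuran-2-yl group of compound 1 and changes the other substituent: methylamino in place of methoxy on an aromatic carbon. In words, this is methylamino in place of methoxy on an aromatic carbon. Within the data shown here, the only measured step, a 70-fold lower number from compound 1 to compound 2 (1.84 log units; beyond the scatter), is large and beyond the scatter, but it concerns ethynyl in place of 1-benzofuran-2-yl and leaves the methoxy untouched. Among the measured compounds shown here, no measured step covers the change made here, so it gives no direct guide to size or direction.

The expectation therefore starts from compound 1 at 20900 nM, with no shift beyond the scatter anticipated in this assay. The expected change is a 1.4-fold lower number from compound 1 to compound 4 (0.14 log units; within the scatter). Compound 4 is estimated at 15000 nM, with an expected range of 4000 nM to 40000 nM.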

Compound 4, half-maximal inhibitory concentration: > 20000 nM
Compound 4 gave a limit, no number (the forecaster's own chance of this, stated with the estimate: 35%); at least 1.3-fold (0.12 log units) between middle value and limit.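

In this assay compound 4 gives > 20000 nM and this is a limit, not a number. The step from compound 1 to compound 4 therefore cannot be read: the limit of > 20000 nM in this assay, at which 2 of the 4 values shown sit. The compounds shown leave open how methylamino in place of methoxy would read with ethynyl in place of 1-benzofuran-2-yl, where a number might be obtained.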